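This account rests on a few compounds, and the source may have more. Where it says the series, first, only, none or still open, it means among the compounds named here.

Compound 1 `O=C(Nc1nnc(-c2ccc(O)c(O)c2)s1)C1CCCCC1`: 34500 nM
Compound 2 `O=C(Nc1nnc(-c2ccc(O)c(O)c2)s1)c1ccc(Cl)cc1`: 47300 nM

Both values come from a functional assay on HeLa cells (Homo sapiens) for cytotoxicity, read by MTT assay, with a stated time of 72 h; a higher number here means a weaker inhibitor, a lower number a stronger inhibitor. Among the compounds with values here, compound 2 stands level with compound 1, the only other compound measured, and the two cannot be ranked. Compound 3 `O=C(Nc1nnc(-c2ccc(O)c(O)c2)s1)c1ccccc1` differs from compound 2 in one place: hydrogen in place of chloro on an aromatic carbon. In words, this is hydrogen in place of chloro on an aromatic carbon, so 4-chlorophenyl becomes phenyl. Within the data shown here, no measured step covers this exact change. Among the measured compounds shown here, the one step that bears on it does so only indirectly, as it exchanges the whole group on the carbonyl carbon: a 1.4-fold higher number from compound 1 to compound 2 (0.14 log units; within the scatter). That larger exchange stayed within the scatter, so no step beyond the scatter, in either direction, is expected in this assay. The expected step is a 1.1-fold lower number from compound 2 to compound 3 (0.05 log units; within the scatter). For compound 3 the estimated value is 42000 nM, with an expected range of 20000 nM to 85000 nM.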

Compound 3, half-maximal inhibitory concentration: 23300 nM
Beside the measured number, compound 3's estimate is 1.8-fold (0.26 log units) above it; the range from low to high includes it.
By their numbers in this assay, from the lowest: compounds 3, 1 and 2 (each within the scatter of the next, the first and the last beyond it).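

In this assay, hydrogen in place of chloro on the aromatic carbon para to a large group gives a 2.0-fold lower number from compound 2 to compound 3 (0.31 log units; beyond the scatter), a modest step and the first here to lie beyond the scatter. It shows that this single position on the ring can shift the number slightly, which the exchange of the whole group on the carbonyl carbon had not shown. Phenyl in place of cyclohexyl on the carbonyl carbon, by contrast, gives a 1.5-fold lower number from compound 1 to compound 3 (0.17 log units; within the scatter), so those two groups cannot be ranked, and nothing available explains either step.

As far as these compounds go, whether the step is particular to chloro remains open, since a methoxy group, an amine or a carboxylic acid at this position could behave differently. Also open, from the compounds shown here alone, is whether any change here would move the number further than this modest step.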